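The source may hold more compounds than are shown below. What is called first, only, known or untested is meant among the compounds shown, and "the series" means these compounds.

Measured so far:
Compound 1 `CCOC(=O)c1c(-c2cccc(-c3ccccc3)c2)[nH]c2cc(Cl)c(Cl)cc2c1=O` — in an ADME assay on HepG2 cells (Homo sapiens) for cytotoxicity, read by luminescence, with a stated time of 72 h (a higher number here means that more compound is needed for the effect, a lower number that less compound is needed), compound 1 stops at the limit > 21500 nM.
Compound 2 `CCOC(=O)c1c(-c2cccc(OC)c2)[nH]c2cc(Cl)c(Cl)cc2c1=O` — in this assay compound 2 also stops at the limit > 21500 nM.
Compound 3 `CCOC(=O)c1c(-c2cccc(-c3ccccc3)c2)[nH]c2cc(OC)c(Cl)cc2c1=O` — in this assay compound 3 likewise stops at the limit > 21500 nM.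

None of these three values is a number; each is a limit of the assay, and this is the whole of what the set shows: the limit of > 21500 nM in this assay, at which 3 of the 3 values shown sit. The change from compound 1 to compound 2 is methoxy in place of phenyl on an aromatic carbon, and its step is a step that the two limits leave unreadable from compound 1 to compound 2. Compound 3 differs from compound 1 in the core, (methoxy in place of chloro on an aromatic carbon), with a step that the two limits leave unreadable from compound 1 to compound 3. Compound 4 `CCOC(=O)c1c(-c2cccc(OC)c2)[nH]c2cc(OC)c(Cl)cc2c1=O` has not yet been measured. It differs from compound 3 by the same change that takes compound 1 to compound 2: methoxy in place of phenyl on an aromatic carbon. The step expected from compound 3 to compound 4 in this assay is a step that the limit leaves unreadable from compound 3 to compound 4, placed beside the earlier, unreadable step. This expectation rests on compound 3 sitting at the limit > 21500 nM. Compound 4 is therefore estimated at 30000 nM, between 15000 nM and 80000 nM, most likely reported again only as a limit.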

Compound 4, half-maximal effective concentration: > 21500 nM
Compound 4: a limit, no number; the forecaster's own chance of this, stated with the estimate: 85%; the middle value is on the limit's open side.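

Compound 4 also stops at a limit, not a number, so the steps to it from compound 3 and compound 2 cannot be read: the limit of > 21500 nM in this assay, at which 4 of the 4 values shown sit. As far as these compounds go, what concentration of any of these four compounds would give the effect in this assay stays open.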